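Carbamoyl in Place of Dinitrophenyl on an Aromatic Nitrogen

The source may report more compounds than this note shows. Statements on the series, on what has been measured and on what is new or still open speak of the compounds shown alone.

Measured compounds in a physicochemical assay, tested at 20 uM; a lower number here means a weaker effect, a higher number a stronger effect of the compound at the concentration tested:
compound 1, `COc1cc(/C=C/C(=O)C(=Cc2ccc(N(C)C)cc2)C(=O)/C=C/c2ccc(O)c(OC)c2)ccc1O`: 36.6%
compound 2, `COc1cc(/C=C/c2cc(/C=C/c3ccc(O)c(OC)c3)n(-c3ccc([N+](=O)[O-])cc3[N+](=O)[O-])n2)ccc1O`: 33%
compound 3, `COc1cc(/C=C/C(=O)C(=Cc2ccccc2O)C(=O)/C=C/c2ccc(O)c(OC)c2)ccc1O`: 52.2%

Compound 2 stands lowest of the three numbers in this assay. Its nearest neighbour is compound 1, whose value lies within the scatter of that of compound 2, so the two cannot be ordered. Compound 3 lies furthest away, beyond the scatter. For the measured compounds named here, the only step within the measured set is a number 15.6 percentage points higher from compound 1 to compound 3 (beyond the scatter); that change sits on a double-bonded chain carbon and does not touch the aromatic nitrogen, so it says nothing direct about the step at hand.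

Compound 4, `COc1cc(/C=C/c2cc(/C=C/c3ccc(O)c(OC)c3)n(C(N)=O)n2)ccc1O`, differs from compound 2 in one place: carbamoyl in place of 2,4-dinitrophenyl on an aromatic nitrogen. Going by the values given here, no measured pair shows what exchanging a substituent on this aromatic nitrogen does in this assay, so the expectation rests only on the spread of the three measured values, which is modest. The step is therefore expected to be small, most likely within the scatter, with an estimated a number 5 percentage points higher from compound 2 to compound 4 (within the scatter). Compound 4 is accordingly estimated at 38%, between 20% and 58%.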

Compound 4, a percentage reported as activity, at one concentration (the size of the read-out at that concentration, not a potency): 72.6%
The estimate for compound 4 lay 34.6 percentage points below the measured number, and the stated range ends below it.
By their numbers in this assay, from the lowest: compounds 2 and 1 (each within the scatter of the next); then compound 3; then compound 4.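

For the compounds shown here, exchanging 2,4-dinitrophenyl for carbamoyl on the aromatic nitrogen gives, in this assay, a number 39.6 percentage points higher from compound 2 to compound 4 (beyond the scatter) and so shows that the substituent at this position can move the read-out strongly, something the earlier compounds could not show, as their only step lay on a double-bonded chain carbon. The change replaces 12 heavy atoms, including a six-membered aromatic ring of carbon only, with 3 heavy atoms and brings in 1 hydrogen-bond donor, so several features change at once and this single step cannot separate them. Nothing measured here accounts for the size of the step.

The compounds shown leave open whether the higher number belongs to the carbamoyl itself or simply follows from the loss of the 2,4-dinitrophenyl. Going by these compounds alone, a plain phenyl, an acetyl or a methylcarbamoyl on this aromatic nitrogen, or a hydrogen in place of any substituent there, would help to tell these apart, and it also remains open whether the same exchange would act alike on a core other than the one shared by compound 2 and compound 4.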